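Amide to urea on the anilide tail of compound 1

This account rests on a few compounds, and the source may have more. Where it says the series, first, only, none or still open, it means among the compounds named here.

Measured so far:
compound 1 `COc1cc(-c2nn(-c3cccc(NC(=O)c4cccc(C(F)(F)F)c4)c3)cc2-c2ccncc2)ccc1Cl`: 10800 nM
compound 2 `O=C(Nc1cccc(-n2cc(-c3ccncc3)c(-c3ccc(Cl)c(O)c3)n2)c1)Nc1cc(C(F)(F)F)cc(C(F)(F)F)c1`: 1310 nM

Compound 1 stands with the higher of the two numbers in a functional assay on NCI-H322M cells (Homo sapiens) for inhibition, read by sulforhodamine B assay, with a stated time of 48 h (a lower number here means a stronger inhibitor of growth, a higher number a weaker inhibitor of growth), and compound 2 with the lower; the gap between them lies beyond the scatter. Going by the values given here, no single-change pair exists between the two, since compound 2 differs from compound 1 in more than one place, so the two values can only be read side by side.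

The step followed here goes from compound 1 to compound 3 `COc1cc(-c2nn(-c3cccc(NC(=O)Nc4ccc(Cl)c(Cl)c4)c3)cc2-c2ccncc2)ccc1Cl`. The change is (3,4-dichlorophenyl)amino in place of 3-(trifluoromethyl)phenyl on a carbonyl carbon. In words of the carbonyl carbon, the (3-(trifluoromethyl)phenyl)carbonyl becomes a (3,4-dichlorophenyl)carbamoyl, so the tail turns from an amide into a urea while the shared core and the methoxy-chlorophenyl group stay as in compound 1.

Among the compounds with values here, compound 2 carries a urea tail too and gives 1310 nM, which lies well under the value of compound 1; that is the only guide available, and it is confounded by the second change in compound 2. The step from compound 1 to compound 3 is therefore expected to run downward, a 3.6-fold lower number from compound 1 to compound 3 (0.56 log units; beyond the scatter), likely beyond the scatter but with wide uncertainty. Compound 3 is expected near 3000 nM, within 800 nM to 12000 nM.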

Compound 3, concentration for 50% growth inhibition: 1690 nM
Beside the measured number, compound 3's estimate is 1.8-fold (0.25 log units) above it; low and high end bracket the measured number.
By their numbers in this assay, from the lowest: compounds 2 and 3 (each within the scatter of the next); then compound 1.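

In this assay, the carbonyl carbon of the anilide tail now has its first reading free of any second change: a 6.4-fold lower number from compound 1 to compound 3 (0.81 log units; beyond the scatter), so this position responds to substitution even with the shared core and the methoxy-chlorophenyl group held constant. The step is a compound change, however, since (3,4-dichlorophenyl)amino replaces 3-(trifluoromethyl)phenyl, turning the amide into a urea, adding one hydrogen-bond donor and altering the substituents on the aromatic ring together, so the drop in the number cannot be assigned to any one of these. Nothing available explains the step.

Still open, going by these compounds, is how the linker and the ring substituents separate, which a (3,4-dichlorophenyl)carbonyl tail and a (3-(trifluoromethyl)phenyl)carbamoyl tail on the core of compound 1 would each address. Also open, on these data alone, is whether the added urea hydrogen matters to the number, a question that a methyl group on that nitrogen or a carbamate oxygen in its place would put to the test.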